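Carboxy to 4-propylcyclohexyl in a three-compound series

The source may report more compounds than this note shows. Statements on the series, on what has been measured and on what is new or still open speak of the compounds shown alone.

Measured in a functional assay on KB-V1 cells (Homo sapiens) for cytotoxicity, read by MTT assay, with a stated time of 72 h (on this read-out lower numbers stand for stronger inhibition and higher numbers for weaker inhibition), so far

- compound 1 `O=C1Nc2ccccc2/C1=N/NC(=S)Nc1ccc2c(c1)CCC2` gives 2850 nM
- compound 2 `O=C1Nc2ccccc2/C1=N/NC(=S)Nc1cc(F)c(F)c(F)c1` gives 2150 nM
- compound 3 `O=C1Nc2ccccc2/C1=N/NC(=S)Nc1ccc(C(=O)O)cc1` gives > 50000 nM (a limit of the assay, not a number)

Compound 3 stands on the limit of > 50000 nM in this assay, at which 1 of the 3 values shown sits, and so carries no number. Compound 1 and compound 2 lie within the scatter of each other, and only these two give numbers.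

Compound 4 `CCCC1CCC(c2ccc(NC(=S)N/N=C3\C(=O)Nc4ccccc43)cc2)CC1` is the next to read. It differs from compound 3 by 4-propylcyclohexyl in place of carboxy on an aromatic carbon with 4-propylcyclohexyl in place of carboxy on an aromatic carbon, para to a large group. Among the compounds with values here, no step between measured compounds that differ in one place is available, so any expectation rests on the values alone. Of the three measured compounds, only compound 3 carries the carboxy group. The other two give numbers, with compound 1 at 2850 nM and compound 2 at 2150 nM in this assay. A large step towards stronger inhibition is therefore expected, with compound 4 coming to rest near that level. The expected change is an at least 25-fold lower number from compound 3 to compound 4 (1.39 log units; beyond the scatter) in this assay on this reasoning. Compound 4 is estimated to read 2000 nM with an expected range from 500 nM to 10000 nM around that figure.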

Compound 4, half-maximal inhibitory concentration: 11000 nM
Beside the measured number, compound 4's estimate is 5.5-fold (0.74 log units) below it; the whole stated range lies below it.
By their numbers in this assay, from the lowest: compounds 2 and 1 (each within the scatter of the next); then compound 4. At a limit, above all of these: compound 3.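

In this assay compound 3 gives > 50000 nM, a limit of the assay and not a number. Putting 4-propylcyclohexyl in place of carboxy on this aromatic carbon, para to a large group, gives an at least 4.5-fold lower number from compound 3 to compound 4 (0.65 log units; beyond the scatter), so this place in the series can carry a large all-carbon ring and still return a number, whereas with carboxy there the read-out stays at the limit. The step sets only a minimum for the size of this change, and its full size cannot be read: the limit of > 50000 nM in this assay, at which 1 of the 4 values shown sits.

The compounds shown leave open whether the change follows the loss of the carboxy group or the arrival of the cyclohexyl ring, as neither a methyl ester nor an amine nor a plain propyl chain at this place stands among them. As far as these compounds go, it also stays open what the propyl chain on the ring contributes, since an unsubstituted cyclohexyl group at the same place is absent from this set and the two cannot be compared.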